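The source may hold more compounds than are shown below. What is called first, only, known or untested is meant among the compounds shown, and "the series" means these compounds.

Working notes on the series. In an assay for inhibition of Indoleamine 2,3-dioxygenase 1 (Homo sapiens), with a stated time of 1 h, tested at 10 uM (on this read-out lower numbers stand for less inhibition and higher numbers for more inhibition at the one concentration tested (going by the name of the read-out)), compound 2 `Oc1ccc(CNc2cc(Br)cc3[nH]ncc23)cc1F` gives 52%. For the measured compounds named here, the only other measured compound, compound 1 `Oc1ccc(CNc2cc(Br)cc3[nH]ncc23)cc1O`, gives 50% in this assay; the two values lie within the scatter of each other, so no order between them can be read from the numbers. Going by the values given here, the single measured step, fluoro in place of hydroxy on an aromatic carbon, gave a number 2 percentage points higher from compound 1 to compound 2 (within the scatter). Compound 3 `Cc1cc(CNc2cc(Br)cc3[nH]ncc23)ccc1O` is not yet measured; it differs from compound 2 by methyl in place of fluoro on an aromatic carbon. Among the compounds with values here, no measured step involves methyl, so the step from compound 1 to compound 2 is the only one that bears on it, and only loosely; it showed a change at this aromatic carbon leaving the read-out in this assay unmoved beyond the scatter. The estimate for compound 3 in this assay is therefore 50%, with a range from 35% to 65%. The expected step is a number 2 percentage points lower from compound 2 to compound 3 (within the scatter), nothing beyond the scatter.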

Compound 3, a percentage reported as inhibition, at one concentration (the size of the read-out at that concentration, not a potency): 28%
The estimate for compound 3 lay 22 percentage points above the measured number, outside the stated range (below it).
By their numbers in this assay, from the lowest: compound 3; then compounds 1 and 2 (each within the scatter of the next).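

For the compounds shown here, compound 3 is the first change at this aromatic carbon, ortho to a hydroxy group, that moves the read-out in this assay beyond the scatter. Methyl in place of fluoro gives a number 24 percentage points lower from compound 2 to compound 3 (beyond the scatter) and methyl in place of hydroxy gives a number 22 percentage points lower from compound 1 to compound 3 (beyond the scatter), so the position is not indifferent to its group, as the earlier pair alone might have suggested. Hydroxy and fluoro remain within the scatter of each other here, and methyl alone stands apart from them. No measurement of any property of these groups bears on this result.

As far as these compounds go, whether the loss is particular to methyl, or would also appear with chloro, methoxy or an amine on this carbon, stays open. The compounds shown also leave open whether these differences hold at other concentrations.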